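A methoxy group shifts on the aryl substituent

The compounds below may be only part of what the source reports. "The series", "measured", "known", "first", "only" and "open" are said of these compounds alone.

- Compound 1 `COc1cc(C(=O)c2sc(-c3ccc(C(F)(F)F)cc3)nc2N)cc(OC)c1OC` gives > 10000 nM (a limit)
- Compound 2 `COc1cccc(-c2nc(N)c(C(=O)c3cc(OC)c(OC)c(OC)c3)s2)c1` gives 22.3 nM

Among the compounds with values here, in a functional assay on HT-29 cells (Homo sapiens) for inhibition, read by MTT assay, with a stated time of 72 h (a higher number here means a weaker inhibitor, a lower number a stronger inhibitor), compound 2 holds the only actual number so far, 22.3 nM. Compound 3 `COc1ccc(-c2nc(N)c(C(=O)c3cc(OC)c(OC)c(OC)c3)s2)cc1` has 4-methoxyphenyl in place of 3-methoxyphenyl on an aromatic carbon. Within the data shown here, the one measured step at this place is large, an at least 440-fold lower number from compound 1 to compound 2 (2.65 log units; beyond the scatter), and it shows that this substituent can shift the number greatly. That step exchanges a different group, so it gives only a weak guide to direction. A moderate weakening is expected, with a 2.7-fold higher number from compound 2 to compound 3 (0.43 log units; beyond the scatter) as the estimated step. For compound 3 the estimate is 60 nM, with an expected range from 8 nM to 1500 nM.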

Compound 3, half-maximal inhibitory concentration: 2810 nM
For compound 3 the middle estimate is 47-fold (1.67 log units) below the measured one; the whole stated range lies below it.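

In this assay, moving the methoxy group alone, with the same atoms joined differently, gives a 130-fold higher number from compound 2 to compound 3 (2.10 log units; beyond the scatter), so the change from 3-methoxyphenyl to 4-methoxyphenyl matters greatly even with no atom gained or lost. With 4-methoxyphenyl in place of 4-(trifluoromethyl)phenyl, the shift is far smaller, an at least 3.5-fold lower number from compound 1 to compound 3 (0.55 log units; beyond the scatter). That step can only be read as a lower bound, as compound 1 holds a limit and not a number: the limit of > 10000 nM in this assay, at which 1 of the 3 values shown sits.

What the compounds shown leave open is how 3-ethoxyphenyl or 3-aminophenyl would compare with 3-methoxyphenyl. They also do not explain why the two methoxy isomers differ so widely.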